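The source may hold more compounds than are shown below. What is called first, only, known or untested is meant among the compounds shown, and "the series" means these compounds.

This account concerns three compounds measured in a functional assay on NSCLC cells (Homo sapiens) for cytotoxicity, with a stated time of 48 h (on this read-out lower numbers stand for stronger inhibition of growth and higher numbers for weaker inhibition of growth), and one that remains to be measured there. Compound 2 `O=C1Nc2ccccc2/C1=C\c1c(Cl)n(Cc2ccccc2)c2ccccc12` carries a benzyl group on the aromatic nitrogen of the shared core; in this assay compound 2 gives 57500 nM, the highest of the three numbers. Within the data shown here, compound 1 `COc1cc2c(/C=C3/C(=O)Nc4ccc(O)cc43)c(Cl)n(Cc3cc(OC)c(OC)c(OC)c3)c2cc1C` gives 32400 nM in this assay, a value that lies within the scatter of the one for compound 2. Compound 3 `COc1cc2c(/C=C3/C(=O)Nc4ccc(Cl)cc43)c(Cl)n(Cc3cc(OC)c(OC)c(OC)c3)c2cc1C` gives 5890 nM in this assay, and the gap from compound 2 down to compound 3 is beyond the scatter. Among the measured compounds shown here, the only step that can be read between measured compounds is a 5.5-fold lower number from compound 1 to compound 3 (0.74 log units; beyond the scatter), a change that sits on a different part of the molecule from the nitrogen substituent.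

Compound 4 `O=C1Nc2ccccc2/C1=C\c1c(Cl)n(CCCc2ccccc2)c2ccccc12` differs from compound 2 by phenethyl in place of phenyl on a saturated chain carbon bound to an aromatic nitrogen. For the measured compounds named here, no measured step in this assay touches the group on the saturated chain carbon bound to the aromatic nitrogen, so the single recorded step offers no guide to the change in hand. Compound 4 is therefore expected to give a number within the scatter of that of compound 2, which corresponds to an expected step of no change at the digits printed from compound 2 to compound 4 (within the scatter). The estimate for compound 4 in this assay is 57500 nM, with an expected range from 20000 nM to 160000 nM.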

Compound 4, concentration for total growth inhibition: 72400 nM
Compound 4: middle estimate off by 1.3-fold (0.10 log units), on the low side, within the range that was stated.
By their numbers in this assay, from the lowest: compound 3; then compounds 1, 2 and 4 (each within the scatter of the next, the first and the last beyond it).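

In this assay, among these compounds, the new pair gives the first reading at this position, the saturated chain carbon bound to an aromatic nitrogen, and it shows a 1.3-fold higher number from compound 2 to compound 4 (0.10 log units; within the scatter) for the change from benzyl to 3-phenylpropyl. Placing phenethyl where phenyl stood, with the aromatic ring kept at the end of the chain, therefore does not separate compound 4 from compound 2 on this read-out, whereas the one earlier step concerned a different part of the molecule. No measurement of another kind bears on this result, so it carries no explanation.

Going by these compounds, it remains open whether a longer chain, or an amine or a carboxylic acid in place of the phenyl on that chain, would also stay within the scatter of compound 2. The reading also rests on a single pair built on the core of compound 2, so whether the same change would read alike with the trimethoxybenzyl-bearing core of compound 3 cannot be told from the compounds shown.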